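Swapping the tetrazole for a benzimidazole on the thioether

The compounds below may be only part of what the source reports. "The series", "measured", "known", "first", "only" and "open" are said of these compounds alone.

Compound 2 `CCOc1cc2ncnc(Nc3ccc(F)c(Cl)c3)c2cc1OC(=O)CSc1nnnn1C` gives 2100 nM in a functional assay on NCI-H1975 cells (Homo sapiens) for inhibition, read by MTT assay, with a stated time of 72 h (a higher number here means a weaker inhibitor, a lower number a stronger inhibitor), the higher of the two numbers measured, the other being compound 1 `C=CC(=O)Oc1cc2c(Nc3ccc(F)c(Cl)c3)ncnc2cc1OCC` at 700 nM. Among the compounds with values here, the only measured step, a 3.0-fold higher number from compound 1 to compound 2 (0.48 log units; beyond the scatter), concerns the carbonyl substituent, not the heteroaryl on the sulfur. Compound 3 `CCOc1cc2ncnc(Nc3ccc(F)c(Cl)c3)c2cc1OC(=O)CSc1nc2ccccc2n1C` carries the change (1-methyl-1H-benzimidazol-2-yl in place of 1-methyl-1H-tetrazol-5-yl on a sulfur). Within the data shown here, no measured step bears on this exchange, so no movement beyond the scatter is expected, and compound 3 is estimated at 2000 nM, within 800 nM to 5000 nM. The expected step is a 1.1-fold lower number from compound 2 to compound 3 (0.02 log units; within the scatter).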

Compound 3, half-maximal inhibitory concentration: 9100 nM
The estimate for compound 3 lay 4.6-fold (0.66 log units) below the measured number; the measured number lies above the stated range.
By their numbers in this assay, from the lowest: compound 1; then compound 2; then compound 3.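

In this assay, the group on the sulfur proves not to be a silent position: 1-methyl-1H-benzimidazol-2-yl in place of 1-methyl-1H-tetrazol-5-yl gives a 4.3-fold higher number from compound 2 to compound 3 (0.64 log units; beyond the scatter). Measured against the vinyl on the carbonyl carbon, the ((1-methyl-1H-benzimidazol-2-yl)sulfanyl)methyl group gives a 13-fold higher number from compound 1 to compound 3 (1.11 log units; beyond the scatter), a larger loss than the tetrazole-bearing group shows. Nothing measured here explains the exchange on the sulfur. On these data alone, it remains open whether a methyl, an imidazole or a chain ending in a carboxylic acid on the sulfur would read closer to compound 2 or to compound 3.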